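The compounds below may be only part of what the source reports. "The series", "measured", "known", "first", "only" and "open" are said of these compounds alone.

Among the compounds with values here, compound 1 `C=CCn1c(=O)/c(=C\c2cccc(F)c2)[nH]c(=O)/c1=C\c1ccccc1OC` is the only member of this small set with a number: in a functional assay on NCI-H1975 cells (Homo sapiens) for cytotoxicity, read by CCK-8 assay, with a stated time of 72 h (a higher number here means a weaker inhibitor, a lower number a stronger inhibitor), compound 1 gives 25600 nM, a weak result. Compound 2 `C=CCn1c(=O)/c(=C\c2ccc(F)c(Br)c2)[nH]c(=O)/c1=C\c1ccccc1OC` is reported in this assay as "not active" (no number reported), with no number attached. Compound 3 `C=CCn1c(=O)/c(=C\c2cccc(Br)c2)[nH]c(=O)/c1=C\c1ccccc1OC` stands likewise: in this assay compound 3 is reported as "not active" (no number reported), so no number places it against compound 1, and compound 2 shares this outcome. Compound 4 `C=CCn1c(=O)/c(=C\c2cccc(Cl)c2)[nH]c(=O)/c1=C\c1ccccc1OC` has not yet been measured. It differs from compound 3 only by chloro in place of bromo on an aromatic carbon. Within the data shown here, no measured step exists for such a change, so the expectation rests on compound 1 with its 25600 nM and on compound 2 and compound 3 without numbers; a step in this assay of no more than the scatter, in either direction, is expected, and weak or absent activity seems most likely. Compound 4 is estimated to give 40000 nM in this assay, with a range from 15000 nM to 150000 nM.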

Compound 4, half-maximal inhibitory concentration: 5100 nM
For compound 4 the middle estimate is 7.8-fold (0.89 log units) above the measured one; measured number below the stated range.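

In this assay, this position on the ring responds clearly to which halogen it carries: chloro in place of fluoro gives a 5.0-fold lower number from compound 1 to compound 4 (0.70 log units; beyond the scatter). Compound 4 also has a number where compound 3, with bromo, is reported only as not active, so that step cannot be read as a size. Activity therefore does not move in one direction from fluoro through chloro to bromo, and no measurement on hand explains this result.

Still open, on these data alone, is how a methyl, a methoxy or a trifluoromethyl group would read at this place in place of chloro.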